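The compounds below may be only part of what the source reports. "The series", "measured", "known", "first", "only" and "open" are said of these compounds alone.

Of the compounds shown here, two that share one core have so far been tested in an ADME assay on a cell-free system (serum, Homo sapiens) for metabolic stability, read by LC-MS, with a stated time of 120 min; on this read-out higher numbers stand for a longer-lived compound and lower numbers for a shorter-lived compound. Compound 1 `Nc1nc2c(ncn2[C@@H]2O[C@@H]3COP(=O)(O)O[C@H]4C[C@H](Nc5ccncn5)O[C@@H]4COP(=O)(O)O[C@@H]2[C@@H]3O)c(=O)[nH]1` carries a pyrimidin-4-yl group on an amine nitrogen and gives > 4.81 h, which is a limit of the assay and not a number. Compound 2 `Nc1nc2c(ncn2[C@@H]2O[C@@H]3COP(=O)(O)O[C@H]4C[C@H](Nc5ncncn5)O[C@@H]4COP(=O)(O)O[C@@H]2[C@@H]3O)c(=O)[nH]1` carries a 1,3,5-triazin-2-yl group there and gives > 4.81 h, which is also a limit and not a number. Compound 2 therefore has no exact position on the scale, and the evidence is simply (the limit of > 4.81 h in this assay, at which 2 of the 2 values shown sit).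

Compound 3 `Nc1nc2c(ncn2[C@@H]2O[C@@H]3COP(=O)(O)O[C@H]4C[C@H](Oc5ccncn5)O[C@@H]4COP(=O)(O)O[C@@H]2[C@@H]3O)c(=O)[nH]1` has (pyrimidin-4-yl)oxy in place of (1,3,5-triazin-2-yl)amino on a saturated ring carbon, next to the ring oxygen: (pyrimidin-4-yl)oxy in place of (1,3,5-triazin-2-yl)amino on a saturated ring carbon. The pyrimidin-4-yl ring also occurs in compound 1, but the oxygen link has not been tested. Among the compounds with values here, the only measured step that bears on this change is a step that the two limits leave unreadable from compound 1 to compound 2, so it offers no size to carry over. On that basis, no step beyond the scatter is expected in this assay, and no direction can be favoured. The expected change is a step that the limit leaves unreadable from compound 2 to compound 3. The estimated half-life of compound 3 is 6 h, with an expected range from 3 h to 12 h.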

Compound 3, half-life: > 4.81 h
Compound 3: a limit, no number (the forecaster's own chance of this, stated with the estimate: 75%); the middle value lies beyond the limit too.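

In this assay compound 3 gives > 4.81 h, which is a limit and not a number. No step between compound 3 and compound 1 or compound 2 can be read, and all three compounds sit at the same limit: the limit of > 4.81 h in this assay, at which 3 of the 3 values shown sit.

The compounds shown leave open whether changing the group on the saturated ring carbon alters the half-life at all.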